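From compound 3 to compound 4: a tail exchange

The source may report more compounds than this note shows. Statements on the series, on what has been measured and on what is new or still open speak of the compounds shown alone.

Values in a functional assay on HCT-116 cells (Homo sapiens) for inhibition (on this read-out lower numbers stand for an effect already at smaller amounts and higher numbers for an effect only at larger amounts of compound), stand as follows
compound 1 `COc1cc(N2CCNCC2)ccc1Nc1nc(NC2CCCCC2)c2nc[nH]c2n1` gives 160 nM
compound 2 `COc1cc(N2CCN(C(=O)N3CCN(C)CC3)CC2)ccc1Nc1nc(NC2CCCCC2)c2nc[nH]c2n1` gives 18 nM
compound 3 `COc1cc(N2CCC(C(=O)N3CCC(N(C)C)C3)CC2)ccc1Nc1nc(NC2CCCCC2)c2nc[nH]c2n1` gives 77 nM

Compound 3 at 77 nM is the second highest of the three numbers. Compound 1 has the highest number at 160 nM and compound 2 has the lowest number at 18 nM on this read-out. Next comes compound 4 `COc1cc(N2CCC(CC(=O)N3CCOCC3)CC2)ccc1Nc1nc(NC2CCCCC2)c2nc[nH]c2n1` with ((morpholin-4-yl)carbonyl)methyl in place of (3-(dimethylamino)pyrrolidin-1-yl)carbonyl on a saturated ring carbon as its change, that is ((morpholin-4-yl)carbonyl)methyl in place of (3-(dimethylamino)pyrrolidin-1-yl)carbonyl on a saturated ring carbon. Within the data shown here, the only measured step is an 8.9-fold lower number from compound 1 to compound 2 (0.95 log units; beyond the scatter) at an amine nitrogen in a ring, so it bears on this change only loosely. Compound 2 at 18 nM and compound 3 at 77 nM both carry an amide with a further amine and both give lower numbers than compound 1, whereas compound 4 carries no such amine. Among the measured compounds shown here, no measured pair isolates this exchange. In this assay the expected step is small and toward a higher number, with a 2.2-fold higher number from compound 3 to compound 4 (0.34 log units; beyond the scatter) as the estimate. Compound 4 is estimated at 170 nM with 60 nM to 480 nM as the expected range.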

Compound 4, half-maximal effective concentration: 70 nM
Beside the measured number, compound 4's estimate is 2.4-fold (0.39 log units) above it; measured number inside the range.
By their numbers in this assay, from the lowest: compound 2; then compounds 4 and 3 (each within the scatter of the next); then compound 1.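

In this assay the exchange gives a 1.1-fold lower number from compound 3 to compound 4 (0.04 log units; within the scatter) and so does not separate ((morpholin-4-yl)carbonyl)methyl from (3-(dimethylamino)pyrrolidin-1-yl)carbonyl on this saturated ring carbon. At this position, a number of this size therefore does not depend on the dimethylamino group, which the entering group lacks. No evidence is at hand to explain this outcome.

The ring, the amine and the added methyl link all change in this one step, so any opposing contributions from these parts remain unresolved. Also open, going by these compounds, are whether the number of compound 2 at 18 nM can be reached at this saturated ring carbon with (4-methylpiperazin-1-yl)carbonyl, and how a carboxylic acid or a longer chain would read there.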